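Replacing the amine of compound 2 with piperidine

The source may hold more compounds than are shown below. What is called first, only, known or untested is meant among the compounds shown, and "the series" means these compounds.

In an in vitro ADME assay on microsomes from liver (Rattus norvegicus) for metabolic stability (a lower number here means slower removal, a higher number faster removal of the compound), compound 2 `CC(C)NC(=O)[C@H]1CC[C@@H](n2/c(=N/C(=O)c3ccc(F)cc3)[nH]c3ccc(CN4CCC[C@H]4C(C)(C)O)cc32)CC1` gives 455 mL.min-1.g-1 and compound 3 `C=CCNS(=O)(=O)c1cccc(C(=O)/N=c2\[nH]c3cc(CN4CCCCC4)ccc3n2[C@H]2CC[C@@H](CO)CC2)c1` gives 314 mL.min-1.g-1 as the two values at the high end, within the scatter of each other. Compound 1 `CC(C)NC(=O)[C@H]1CC[C@@H](n2/c(=N/C(=O)c3ccc(C#N)c(F)c3)[nH]c3ccc(CN4CCC(C(C)(C)O)CC4)cc32)CC1` gives 29 mL.min-1.g-1 and stands beyond the scatter on the low side of compound 2.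

Compound 4 `CC(C)NC(=O)[C@H]1CC[C@@H](n2/c(=N/C(=O)c3ccc(F)cc3)[nH]c3ccc(CN4CCCCC4)cc32)CC1` differs from compound 2 by piperidin-1-yl in place of 2-(1-hydroxy-1-methylethyl)pyrrolidin-1-yl on a saturated chain carbon bound to an aromatic carbon with piperidin-1-yl in place of 2-(1-hydroxy-1-methylethyl)pyrrolidin-1-yl on a saturated chain carbon bound to an aromatic carbon. Within the data shown here, no measured step isolates this change. Compound 3 also carries piperidin-1-yl there and gives 314 mL.min-1.g-1 so only a small fall, within the scatter, is expected in this assay. The estimated change is a 1.5-fold lower number from compound 2 to compound 4 (0.18 log units; within the scatter) in size. Compound 4 is estimated at 300 mL.min-1.g-1 with 120 mL.min-1.g-1 to 650 mL.min-1.g-1 as the expected range.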

Compound 4, intrinsic clearance in microsomes: 451 mL.min-1.g-1
Compound 4: middle estimate off by 1.5-fold (0.18 log units), on the low side; the range from low to high includes it.
By their numbers in this assay, from the lowest: compound 1; then compounds 3, 4 and 2 (each within the scatter of the next).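

On a saturated chain carbon bound to an aromatic carbon, piperidin-1-yl in place of 2-(1-hydroxy-1-methylethyl)pyrrolidin-1-yl gives a 1.0-fold lower number from compound 2 to compound 4 (0.00 log units; within the scatter) in this assay. At this position, the loss of the hydroxy-bearing substituent and its defined stereocentre therefore leaves the read-out unmoved, and clearance stays high. Nothing available explains this lack of change.

Compound 1 at 29 mL.min-1.g-1 differs from compound 4 in more than one place, so the origin of its lower number remains unassigned. Going by these compounds, how morpholin-4-yl would read at this position also remains open.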